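Two hydroxyls replace two methoxys on the hydrazone aryl

A few compounds are considered here, and "the series" means these few. Any claim that something is new, unique, unknown or untested is made for them only; others in the source may bear on it.

Compound 1 `COc1ccc(OC)c(/C=N/NC(=O)Nc2ccc(Oc3ccnc(-c4nncn4CCN(C)C)c3)c(F)c2)c1` is the weakest of the three measured compounds in a functional assay on HT-29 cells (Homo sapiens) for cytotoxicity, read by MTT assay, with a stated time of 72 h (a higher number here means a weaker inhibitor, a lower number a stronger inhibitor), where compound 1 gives 2070 nM. Compound 2 `CN(C)CCn1cnnc1-c1cc(Oc2ccc(NC(=O)N/N=C/c3ccc(O)cc3)cc2F)ccn1` gives 1920 nM, and compound 3 `COc1ccc(/C=N/NC(=O)Nc2ccc(Oc3ccnc(-c4nncn4CCN(C)C)c3)c(F)c2)cc1O` gives 960 nM. The step of a 1.1-fold lower number from compound 1 to compound 2 (0.03 log units; within the scatter) is small, while a 2.2-fold lower number from compound 1 to compound 3 (0.33 log units; beyond the scatter) is modest but real. Compound 4 `CN(C)CCn1cnnc1-c1cc(Oc2ccc(NC(=O)N/N=C/c3ccc(O)cc3O)cc2F)ccn1` arises from compound 1 by the change (2,4-dihydroxyphenyl in place of 2,5-dimethoxyphenyl on a carbon with a double bond to nitrogen). Both of the measured steps from compound 1 swap the same ring for a hydroxylated one, and neither moved far, so a small to modest lowering in this assay is expected for compound 4, roughly a 1.6-fold lower number from compound 1 to compound 4 (0.20 log units; within the scatter). Compound 4 is therefore estimated at 1300 nM, with a range from 600 nM to 2800 nM.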

Compound 4, half-maximal inhibitory concentration: 52600 nM
For compound 4 the middle estimate is 40-fold (1.61 log units) below the measured one; the measured number lies above the stated range.
By their numbers in this assay, from the lowest: compounds 3, 2 and 1 (each within the scatter of the next, the first and the last beyond it); then compound 4.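

Until this point, every ring on the carbon with a double bond to nitrogen had kept the numbers in this assay within a modest span, but the 2,4-dihydroxyphenyl ring breaks from them, with a 25-fold higher number from compound 1 to compound 4 (1.41 log units; beyond the scatter) and a 55-fold higher number from compound 3 to compound 4 (1.74 log units; beyond the scatter) in the same assay. The cleanest reading is the single added hydroxy on an aromatic carbon, which gives a 27-fold higher number from compound 2 to compound 4 (1.44 log units; beyond the scatter) and shows that this position can tolerate one change and lose far more with another. No measurement shown accounts for this loss. Whether it belongs to that hydroxy as such remains open, as the compounds shown do not tell what an amine in its place would do.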